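The compounds below may be only part of what the source reports. "The series", "measured", "known", "first", "only" and "open" are said of these compounds alone.

Working notes on the series. Compound 1 `O=C1/C(=N\NC(=S)Nc2ccc(Cl)cc2)c2cc(Cl)ccc2N1Cc1ccc(Cl)cc1`, compound 2 `O=C1/C(=N\NC(=S)Nc2ccc(Cl)cc2)c2cc(Cl)ccc2N1Cc1ccc(F)cc1` and compound 3 `Cc1ccc(NC(=S)N/N=C2\C(=O)N(Cc3ccc(F)cc3)c3ccc(Br)cc32)cc1` were measured in a functional assay on L1210 cells (Mus musculus), with a stated time of 48 h; a lower number here means a stronger inhibitor, a higher number a weaker inhibitor. Compound 1 gives 124000 nM, compound 2 gives 103000 nM and compound 3 gives 190000 nM; all three values lie within the scatter of one another. Compound 2 and compound 1 differ by one change, (chloro in place of fluoro on an aromatic carbon), which gave a 1.2-fold higher number from compound 2 to compound 1 (0.08 log units; within the scatter). How the core of compound 3 differs from the core of compound 2 is not broken down here. Compound 4 `Cc1ccc(NC(=S)N/N=C2\C(=O)N(Cc3ccc(Cl)cc3)c3ccc(Br)cc32)cc1`, not yet measured, differs from compound 3 by chloro in place of fluoro on an aromatic carbon, the same change made from compound 2 to compound 1. Because a 1.2-fold higher number from compound 2 to compound 1 (0.08 log units; within the scatter) stayed within the scatter, a step of about a 1.2-fold higher number from compound 3 to compound 4 (0.06 log units; within the scatter) is expected in this assay. Compound 4 is therefore estimated at 220000 nM, between 110000 nM and 440000 nM.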

Compound 4, half-maximal inhibitory concentration: >= 500000 nM
Compound 4 gave a limit, no number (the forecaster's own chance of this, stated with the estimate: 15%); middle value at least 2.2-fold (0.35 log units) from the limit.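

In this assay compound 4 gives >= 500000 nM, which is a limit of the assay and not a number. Chloro in place of fluoro on the benzyl group gave an at least 2.6-fold higher number from compound 3 to compound 4 (0.42 log units; beyond the scatter), so on this core the change moved the read-out beyond the scatter. This does not show that the size of the step carries from one core to the other, or that it fails to: the same change on two cores in this assay, a 1.2-fold higher number (0.08 log units; within the scatter) from compound 2 to compound 1 and an at least 2.6-fold higher number (0.42 log units; beyond the scatter) from compound 3 to compound 4; the limit leaves it open whether they differ

The compounds shown leave open what an amine or a carboxylic acid in place of the halogen on the benzyl group would give on either core. Also open, from the compounds shown here alone, is how a longer chain in place of the benzyl group would read in this assay.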